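The source may hold more compounds than are shown below. What is called first, only, known or untested is meant among the compounds shown, and "the series" means these compounds.

Compound 1 `C[C@H](NC(=O)c1nnn(Cc2ccc(F)cc2)c1C(F)(F)F)c1ccc(C(=O)O)cc1`: > 10000 nM
Compound 2 `C[C@H](NC(=O)c1c(C(F)(F)F)nnn1Cc1ccc(F)cc1)c1ccc(C(=O)O)cc1`: 2320 nM

Two compounds share one core and were tested in a functional assay on CHO cells for antagonist activity at prostaglandin E2 receptor EP4 subtype (Homo sapiens), read by calcium flux, with a stated time of 15 min; a higher number here means a weaker inhibitor, a lower number a stronger inhibitor. For compound 1 the result is a limit of the assay rather than a number, (the limit of > 10000 nM in this assay, at which 1 of the 2 values shown sits). Among the measured compounds shown here, compound 2 gives the only numeric value, 2320 nM, in this assay.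

Compound 3 `C[C@H](NC(=O)c1c(C(F)(F)F)nnn1CCOc1ccc(F)cc1)c1ccc(C(=O)O)cc1` differs from compound 2 by (4-fluorophenoxy)methyl in place of 4-fluorophenyl on a saturated chain carbon bound to an aromatic nitrogen. For the measured compounds named here, no measured step of this kind exists here, so the size of the change is uncertain. The step of a 1.1-fold higher number from compound 2 to compound 3 (0.03 log units; within the scatter) is expected to stay within the usual scatter. Compound 3 is estimated at 2500 nM, with a range from 700 nM to 9000 nM.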

Compound 3, half-maximal inhibitory concentration: 276 nM
Estimate against measurement, compound 3: 9.1-fold (0.96 log units) above, and the stated range ends above it.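

In this assay, among the compounds shown here, the swap of 4-fluorobenzyl for 2-(4-fluorophenoxy)ethyl gives an 8.4-fold lower number from compound 2 to compound 3 (0.92 log units; beyond the scatter) and is the first measured step at this place. It shows that the group carried on the aromatic nitrogen matters, with the change here leading to a stronger inhibitor. Nothing among the measured results explains why this chain does better.

Going by these compounds, whether the gain comes from the added length or from the oxygen stays open. A 3-(4-fluorophenyl)propyl chain, with carbon in place of that oxygen, would separate the two.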